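The compounds below may be only part of what the source reports. "The series", "measured", "known", "first", "only" and "open" are said of these compounds alone.

Going by the values given here, compound 1, with the structure `Cc1ccc(-c2cc3ccccc3[nH]2)cc1`, gives the lowest number of the three compounds measured so far in an assay on isolated protein for inhibition of Aromatase (Homo sapiens), read by fluorescence, using NADPH, with a stated time of 30 min, tested at 50 uM (on this read-out higher numbers stand for more inhibition at the one concentration tested (going by the name of the read-out) and lower numbers for less inhibition), where compound 1 gives 9.33%. Compound 2, `Cc1ccccc1-c1cc2ccccc2[nH]1`, is the nearest to it; in this assay compound 2 gives 27.1%, which stands higher than compound 1 by a margin beyond the usual scatter. Compound 3, `N#Cc1ccc2[nH]c(-c3cccnc3)cc2c1`, is the furthest from compound 1; in this assay compound 3 gives 93.7%, far above compound 1 and well beyond the scatter.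

Compound 4, `Nc1ccc(-c2cc3ccccc3[nH]2)cc1`, has not yet been measured. It differs from compound 1 in one place, (amino in place of methyl on an aromatic carbon). Among the compounds with values here, no step between two measured compounds matches this change, so there is no measured pair to lean on, and the three values only show that a small change on the shared core can move the read-out either a little or a great deal.

Compound 4 is therefore expected to sit somewhat above compound 1, and the step from compound 1 to compound 4 in this assay is estimated at a number 12.7 percentage points higher from compound 1 to compound 4 (beyond the scatter). The estimate for compound 4 in this assay is 22%, with an expected range from 3% to 50%.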

Compound 4, a percentage reported as inhibition, at one concentration (the size of the read-out at that concentration, not a potency): 46.2%
Beside the measured number, compound 4's estimate is 24.2 percentage points below it; low and high end bracket the measured number.
By their numbers in this assay, from the lowest: compound 1; then compound 2; then compound 4; then compound 3.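

In this assay, going by these compounds alone, putting amino in place of methyl on the aromatic carbon para to a group of 9 heavy atoms gives the first measured step at this position, a number 36.9 percentage points higher from compound 1 to compound 4 (beyond the scatter), and that step is large. By count the swap is small, one heavy atom for one heavy atom, with no ring and no net charge on either side, the only differences being the element and the hydrogen-bond donor and acceptor that amino brings, so this position is clearly not indifferent to what sits on it. Nothing measured here accounts for the size of the step, and its reason remains unknown.

The compounds shown leave open whether the gain belongs to amino itself or would also appear with a hydroxyl, a methoxy, a dimethylamino or an acetamide group on the same carbon. They also leave open whether amino would give a step of similar size on other carbons of this ring, or on a core that carries the nitrile found in compound 3.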